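Working notes: tolerated concentration across the shared core

The source may report more compounds than this note shows. Statements on the series, on what has been measured and on what is new or still open speak of the compounds shown alone.

Compound 1 `CCc1ccc2[nH]c(=O)c(CN(Cc3ccc(C(C)(C)C)cc3)Cc3ccc(F)c(F)c3)cc2c1` and compound 2 `Cc1ccc2cc(CN(Cc3ccc(F)cc3)C(=O)c3ccccc3)c(=O)[nH]c2c1` share the core and have both been tested in a toxicity assay on MDCK cells (Canis lupus familiaris) for cytotoxicity, read by crystal violet staining, with a stated time of 48 h; a lower number here means that less compound is tolerated, a higher number that more compound is tolerated. In this assay compound 1 gives > 33000 nM, which is a limit of the assay and not a number. In this assay compound 2 gives > 33000 nM, again a limit rather than a number. Compound 1 thus stands at the limit, together with every value shown so far: the limit of > 33000 nM in this assay, at which 2 of the 2 values shown sit. Among the measured compounds shown here, no step between two measured compounds is available, so the measured pairs say nothing about how a change on the substituent at the amine nitrogen moves the tolerated concentration.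

Compound 3 `CCc1ccc2[nH]c(=O)c(CN(Cc3ccc(OCOC)cc3)Cc3ccc(C(C)(C)C)cc3)cc2c1` has not yet been measured in this assay. Against compound 1 the change is 4-(methoxymethoxy)phenyl in place of 3,4-difluorophenyl on a saturated chain carbon bound to an amine nitrogen, in words 4-(methoxymethoxy)phenyl in place of 3,4-difluorophenyl on a saturated chain carbon bound to an amine nitrogen. With both measured values sitting at the limit, no shift beyond the scatter is expected, which amounts to an estimated step that the limit leaves unreadable from compound 1 to compound 3. Compound 3 is estimated at 40000 nM, within 15000 nM to 100000 nM, and most likely to be reported only as a limit once more.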

Compound 3, half-maximal cytotoxic concentration: > 10000 nM
Compound 3: only a limit was reported (the forecaster's own chance of this, stated with the estimate: 75%); the middle value does not contradict the limit.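

In this assay compound 3 gives > 10000 nM as a limit and not a number. Compound 1 gives > 33000 nM as a limit as well. Among the compounds shown here, no step from compound 1 to compound 3 can be read. The compounds shown leave open at what concentration either compound stops being tolerated, and whether 4-(methoxymethoxy)phenyl in place of 3,4-difluorophenyl changes that concentration.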